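The source may report more compounds than this note shows. Statements on the series, on what has been measured and on what is new or still open speak of the compounds shown alone.

Of the compounds shown here, three have so far been measured in an assay on ileum (strain Hartley) for inhibition of histamine H1 receptor (Cavia porcellus), with a stated time of 2 min; on this read-out lower numbers stand for smaller maximal responses and higher numbers for larger maximal responses. Compound 1, `CC(CO)(CO)Nc1nc2ccccc2[nH]1`, gives 55% in this assay. Compound 2, `CC(CO)(CO)NCc1nc2ccccc2[nH]1`, gives 14.2% in this assay. Compound 3, `CC(C)(CO)NCC(C)(C)N1C(=O)c2ccccc2C1=O`, gives 20% in this assay. On these three numbers compound 3 stands second highest: its nearest neighbour is compound 2, whose value lies within the scatter of its own, and its furthest is compound 1, whose value lies beyond the scatter above it. For the measured compounds named here, no step between two measured compounds that differ in a single place is available here, so nothing measured yet shows how one change alone moves this read-out.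

The account now follows the step from compound 3 to compound 4, `CC(C)CNCC(C)(C)N1C(=O)c2ccccc2C1=O`. The change is isobutyl in place of 1-(hydroxymethyl)-1-methylethyl on an amine nitrogen. Going by the values given here, with no comparable measured step to lean on, compound 4 is expected to stay close to compound 3, with a step of a number 4 percentage points higher from compound 3 to compound 4 (within the scatter) that may well fall within the scatter. Compound 4 is therefore estimated at 24% in this assay, in a range from 8% to 48%.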

Compound 4, largest response reached (Emax), in percent of the reference or control that the assay uses: 18%
Beside the measured number, compound 4's estimate is 6 percentage points above it, and the stated range covers the measured number.
By their numbers in this assay, from the lowest: compounds 2, 4 and 3 (each within the scatter of the next); then compound 1.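

In this assay, for the compounds shown here, isobutyl in place of 1-(hydroxymethyl)-1-methylethyl on an amine nitrogen gives a number 2 percentage points lower from compound 3 to compound 4 (within the scatter), the first step in this set that isolates a change in one place. At this position, then, the exchange takes away the hydroxyl-bearing group, with the hydrogen-bond donor and acceptor counted on it, without separating the two compounds on this read-out. Nothing available explains why the two compounds read alike.

Going by these compounds, it remains open whether a group of another kind on this amine nitrogen, such as a carboxylic acid, a cyclohexyl ring or a longer chain, would move this assay beyond the scatter. On these data alone, it is also open whether the same exchange would behave alike on a different core.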